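Working notes: allyloxycarbonyl step from compound 3

The source may hold more compounds than are shown below. What is called first, only, known or untested is meant among the compounds shown, and "the series" means these compounds.

Measured in a functional assay on MCF7 cells (Homo sapiens) for inhibition, read by radiometric assay and XTT assay; on this read-out higher numbers stand for weaker inhibition and lower numbers for stronger inhibition:
- compound 1 `CCCCCCCC[C@@]1(C)SC(O)=C(C)C1=O` gives 48 ug/mL
- compound 2 `CCCCCC[C@@]1(C)SC(=O)C=C1OC` gives 9.4 ug/mL
- compound 3 `CCCCCCCC[C@@]1(C)SC(=O)C=C1OC` gives 16.4 ug/mL

Compound 3, at 16.4 ug/mL, lies within the scatter of compound 2 and well under compound 1, which gives 48 ug/mL. The next compound to be read in this assay is compound 4 `C=CCOC(=O)OC1=CC(=O)S[C@]1(C)CCCCCCCC`, which has allyloxycarbonyl in place of methyl on an oxygen on an unsaturated carbon. For the measured compounds named here, no measured step changes the group at this place. Going by the values given here, the only single-place step is a 1.7-fold higher number from compound 2 to compound 3 (0.24 log units; within the scatter), a change on a saturated chain carbon, so it bears on this change only indirectly. Among the compounds with values here, with no measured precedent, no shift beyond the scatter is expected, though the uncertainty is wide. The expected step is a 1.3-fold lower number from compound 3 to compound 4 (0.10 log units; within the scatter), which stays within the scatter. For compound 4 the estimated value is 13 ug/mL, with an expected range from 4.5 ug/mL to 40 ug/mL.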

Compound 4, half-maximal inhibitory concentration: 37.3 ug/mL
For compound 4 the middle estimate is 2.9-fold (0.46 log units) below the measured one, and the stated range covers the measured number.
By their numbers in this assay, from the lowest: compounds 2 and 3 (each within the scatter of the next); then compounds 4 and 1 (each within the scatter of the next).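

In this assay the oxygen on an unsaturated carbon proves sensitive to the group it carries: allyloxycarbonyl in place of methyl gives a shift beyond the scatter toward weaker inhibition (a 2.3-fold higher number from compound 3 to compound 4 (0.36 log units; beyond the scatter)). The chain change, by contrast, stays within the scatter (a 1.7-fold higher number from compound 2 to compound 3 (0.24 log units; within the scatter)), so this is the only single-place step shown that clearly moves the read-out, and it shows that methyl cannot be exchanged freely for allyloxycarbonyl here. Nothing available accounts for the shift.

The compounds shown leave open whether the weaker inhibition follows from the carbonyl of the entering group, its allyl end or its overall count of heavy atoms. An ethyl or a benzyl group on this oxygen, or an acetyl group, would help separate these readings.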